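Swapping methoxy for chloro on the benzyl arm

This account rests on a few compounds, and the source may have more. Where it says the series, first, only, none or still open, it means among the compounds named here.

Three measured compounds share one core and differ only in the group carried by a ring amine nitrogen. Compound 1 `CN1CCN(CC(=O)Nc2ccc(-c3nc(-c4ccccc4)c(-c4ccccc4)n3C)cc2)CC1` gives 1.1% in a functional assay on MCF7 cells (Homo sapiens) for cytotoxicity, read by MTT assay, with a stated time of 24 h, tested at 0.64 ug/mL; on this read-out lower numbers stand for a weaker effect and higher numbers for a stronger effect at the one concentration tested; compound 2 `CCN1CCN(CC(=O)Nc2ccc(-c3nc(-c4ccccc4)c(-c4ccccc4)n3C)cc2)CC1` gives 4.7%; compound 3 `COc1ccc(CN2CCN(CC(=O)Nc3ccc(-c4nc(-c5ccccc5)c(-c5ccccc5)n4C)cc3)CC2)cc1` gives 1%. Compound 3 holds the lowest of the three numbers, yet a number 0.1 percentage points lower from compound 1 to compound 3 (within the scatter) and a number 3.7 percentage points lower from compound 2 to compound 3 (within the scatter), so all three sit together. Compound 4 `Cn1c(-c2ccc(NC(=O)CN3CCN(Cc4ccc(Cl)cc4)CC3)cc2)nc(-c2ccccc2)c1-c1ccccc1` differs from compound 3 by chloro in place of methoxy on an aromatic carbon. Within the data shown here, no measured step touches the 4-methoxyphenyl itself; the nearest comparisons are the exchanges at the same ring nitrogen, which all stayed within the scatter. The expected step is therefore a number 1 percentage points higher from compound 3 to compound 4 (within the scatter), nothing beyond the scatter. Compound 4 is estimated at 2%, within a range from 0% to 10%.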

Compound 4, a percentage reported as activity, at one concentration (the size of the read-out at that concentration, not a potency): 4.8%
Beside the measured number, compound 4's estimate is 2.8 percentage points below it; the range from low to high includes it.
By their numbers in this assay, from the lowest: compounds 3, 1, 2 and 4 (each within the scatter of the next).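

Placing a new group on the aromatic ring of the benzyl arm, chloro in place of methoxy, gives a number 3.8 percentage points higher from compound 3 to compound 4 (within the scatter) in this assay. The comparisons with the small groups on the ring nitrogen read the same way, a number 0.1 percentage points higher from compound 2 to compound 4 (within the scatter) and a number 3.7 percentage points higher from compound 1 to compound 4 (within the scatter), so even a change on that outer ring leaves all four compounds within the scatter of one another. No available evidence bears on this result. Still open, going by these compounds, is whether an amine or a carboxylic acid on that aromatic carbon would give a number beyond the scatter of these four.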